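Chain shortening and a chloro group on the amide side

The source may hold more compounds than are shown below. What is called first, only, known or untested is meant among the compounds shown, and "the series" means these compounds.

Measured so far:
compound 1 `CCCC(=O)Nc1ccc(S(=O)(=O)Oc2ccccc2C(C)C)cc1` — 950 nM
compound 2 `CCCCCC(=O)Nc1ccc(S(=O)(=O)Oc2ccccc2C(C)C)cc1` — 6300 nM
compound 3 `CCCCCC(=O)Nc1ccc(S(=O)(=O)Oc2ccccc2I)cc1` — 9600 nM

In a functional assay on HT-1080 cells (Homo sapiens) for antiproliferative activity, read by sulforhodamine B assay, with a stated time of 48 h (on this read-out higher numbers stand for weaker inhibition and lower numbers for stronger inhibition), compound 2 gives 6300 nM, the second highest of the three numbers. Its nearest neighbour is compound 3, as a 1.5-fold higher number from compound 2 to compound 3 (0.18 log units; within the scatter) shows, a gap within the scatter. Its furthest neighbour is compound 1; the step of a 6.6-fold higher number from compound 1 to compound 2 (0.82 log units; beyond the scatter) lies beyond the scatter.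

Compound 4 `CC(C)c1ccccc1OS(=O)(=O)c1ccc(NC(=O)CCl)cc1` is not yet measured. It differs from compound 2 in one place: chloro in place of butyl on a saturated chain carbon bound to a carbonyl carbon. Going by the values given here, the one measured step that bears on this is a 6.6-fold higher number from compound 1 to compound 2 (0.82 log units; beyond the scatter), where lengthening the amide chain raised the number. Compound 4 cuts that chain back further than compound 1 and puts a chloro group at the end, a change without any measured counterpart in this series. Taking the chain step as a guide, the number for compound 4 is expected to fall against compound 2, by about an 11-fold lower number from compound 2 to compound 4 (1.02 log units; beyond the scatter), with wide uncertainty. The estimate for compound 4 in this assay is 600 nM, with a range from 150 nM to 2500 nM.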

Compound 4, half-maximal inhibitory concentration: 1000 nM
Estimate against measurement, compound 4: 1.7-fold (0.22 log units) below; low and high end bracket the measured number.
By their numbers in this assay, from the lowest: compounds 1 and 4 (each within the scatter of the next); then compounds 2 and 3 (each within the scatter of the next).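

In this assay, chloro in place of butyl on the saturated chain carbon bound to a carbonyl carbon gives a 6.3-fold lower number from compound 2 to compound 4 (0.80 log units; beyond the scatter) and so brings the number down by a step beyond the scatter. Chloro in place of ethyl at the same carbon gives a 1.1-fold higher number from compound 1 to compound 4 (0.02 log units; within the scatter) and stays within the scatter, so compound 1 and compound 4 cannot be told apart here, even though the two groups differ. No measurement on hand gives a cause for either step.

The compounds shown leave open whether the chloro group itself matters or only the shorter chain; a methyl, bromo or hydroxyl group at that carbon would bear on this. Also open, as far as these compounds go, is whether iodo in place of isopropyl stays within the scatter when the chloromethyl amide is present, as it does from compound 2 to compound 3.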